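Removing a carbonyl-bearing cap from a sulfur chain end

The source may hold more compounds than are shown below. What is called first, only, known or untested is meant among the compounds shown, and "the series" means these compounds.

Measured compounds:
compound 1, `O=C(NCCCCCCSSCCCCCCNC(=O)c1cc(-c2ccncc2)n[nH]1)c1cc(-c2ccncc2)n[nH]1`: 8930 nM
compound 2, `C=CCOC(=O)SCCCCCCNC(=O)c1cc(-c2ccncc2)n[nH]1`: 32900 nM

In a functional assay on HCT-116 cells (Homo sapiens) for inhibition, read by MTT assay, with a stated time of 96 h (on this read-out lower numbers stand for stronger inhibition of growth and higher numbers for weaker inhibition of growth), compound 1 gives 8930 nM. Compound 2 gives 32900 nM in this assay, the higher of the two numbers, so its growth inhibition is the weaker one, and the gap to compound 1 lies beyond the scatter.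

Compound 3, `CSCCCCCCNC(=O)c1cc(-c2ccncc2)n[nH]1`, is still unmeasured. It differs from compound 2 in one place: methyl in place of allyloxycarbonyl on a sulfur. Among the compounds with values here, no measured pair shows this change, so the expectation rests on compound 2 alone. The step from compound 2 to compound 3 is expected to be small, a 1.4-fold higher number from compound 2 to compound 3 (0.14 log units; within the scatter), most likely toward a higher number or none beyond the scatter. For compound 3 the estimate is 45000 nM, with a range from 12000 nM to 170000 nM.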

Compound 3, concentration for 50% growth inhibition: > 50000 nM
Compound 3: only a limit was reported; the forecaster's own chance of this, stated with the estimate: 25%; at least 1.1-fold (0.04 log units) between middle value and limit.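

Compound 3 gives > 50000 nM in this assay, and this value is a limit of the assay, not a number. Methyl in place of allyloxycarbonyl on the sulfur therefore gives an at least 1.5-fold higher number from compound 2 to compound 3 (0.18 log units; that floor lies within the scatter), which fixes only a floor for the change, and that floor alone does not show a real loss of growth inhibition. What is new is that this sulfur end has now been read with a small methyl, and the result gives no sign of stronger growth inhibition than with allyloxycarbonyl, although the reading stops at the top of the tested range: the limit of > 50000 nM in this assay, at which 1 of the 3 values shown sits.

On these data alone, how a free thiol or an acetyl group on this sulfur would read remains open. So does the effect of a longer chain carrying the sulfur.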